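The compounds below may be only part of what the source reports. "The series", "measured", "known", "first", "only" and "open" are said of these compounds alone.

In a functional assay on PANC-1 cells (Homo sapiens) for cytotoxicity, read by fluorescence, with a stated time of 24 h (a higher number here means a weaker inhibitor, a lower number a stronger inhibitor), compound 1 `CC(C)=CCC/C(C)=C/Cc1c(CCC(=O)c2ccc(O)cc2O)ccc(O)c1O` gives 42900 nM and compound 3 `CC(C)=CCCC1(C)CCc2c(CCC(=O)c3ccc(O)cc3O)ccc(O)c2O1` gives 59500 nM, two values within the scatter of each other. For compound 2 `C/C(=C\Cc1c(CCC(=O)c2ccc(O)cc2O)ccc(O)c1O)CCCC(C)(C)O` the assay reports only a limit, > 75000 nM.

Compound 4 `COC(C)(C)CCCC1(C)CCc2c(CCC(=O)c3ccc(O)cc3O)ccc(O)c2O1` has not yet been measured. It differs from compound 3 as follows: 2-methoxy-2-methylpropyl in place of 2-methylprop-1-en-1-yl on a saturated chain carbon, two bonds along the chain from a saturated ring carbon. In words, 2-methoxy-2-methylpropyl takes the place of 2-methylprop-1-en-1-yl on a saturated chain carbon, two bonds along the chain from a saturated ring carbon.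

The closest measured change removes the same group and brings in 2-hydroxy-2-methylpropyl instead: an at least 1.7-fold higher number from compound 1 to compound 2 (0.24 log units; that floor lies within the scatter). That size is only a floor because of the limit of > 75000 nM in this assay, at which 1 of the 3 values shown sits. It points weakly towards a higher number, which in this assay means a weaker inhibitor, but it is a single step at a different place in the molecule. A small rise that stays within the scatter is therefore expected, and the expected step is a 1.2-fold higher number from compound 3 to compound 4 (0.07 log units; within the scatter). For compound 4 the estimated value is 70000 nM, with an expected range from 40000 nM to 120000 nM.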

Compound 4, half-maximal inhibitory concentration: 48300 nM
Compound 4: middle estimate off by 1.4-fold (0.16 log units), on the high side; low and high end bracket the measured number.
By their numbers in this assay, from the lowest: compounds 1, 4 and 3 (each within the scatter of the next). At a limit, above all of these: compound 2.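

In this assay, exchanging 2-methylprop-1-en-1-yl for 2-methoxy-2-methylpropyl on a saturated chain carbon, two bonds along the chain from a saturated ring carbon, gives a 1.2-fold lower number from compound 3 to compound 4 (0.09 log units; within the scatter). Among these compounds, at this place, then, the end group can lose its double bond and gain an oxygen with no step beyond the scatter, which the earlier compounds could not show, since their only step was at a different place and ended in a limit. For compound 2 the result is only a limit: the limit of > 75000 nM in this assay, at which 1 of the 4 values shown sits.

The compounds shown leave open what 2-hydroxy-2-methylpropyl would give at this same place on the core of compound 3. They also leave open whether an amine, a carboxylic acid or a longer chain here would move the number beyond the scatter.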